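A few compounds are considered here, and "the series" means these few. Any claim that something is new, unique, unknown or untested is made for them only; others in the source may bear on it.

Measured compounds:
- compound 1 `Cc1ccc(S(=O)(=O)n2cc(COC3=C/C(=N\c4ccccc4)c4ccccc4C3=O)nn2)cc1` gives 5370 nM
- compound 2 `Cc1ccc(S(=O)(=O)n2cc(COC3=C/C(=N\c4ccc(Cl)cc4)c4ccccc4C3=O)nn2)cc1` gives 9440 nM
- compound 3 `Cc1ccc(/N=C2\C=C(OCc3cn(S(=O)(=O)c4ccc(C)cc4)nn3)C(=O)c3ccccc32)cc1` gives 3610 nM

These three compounds were tested in a functional assay on HCT-116 cells (Homo sapiens) for cytotoxicity, read by MTT assay, with a stated time of 72 h; on this read-out higher numbers stand for weaker inhibition and lower numbers for stronger inhibition. On these numbers compound 1 stands second highest of the three, and its steps to both neighbours lie within the scatter: a 1.8-fold higher number from compound 1 to compound 2 (0.24 log units; within the scatter) and a 1.5-fold lower number from compound 1 to compound 3 (0.17 log units; within the scatter). The step between the other two is modest: a 2.6-fold lower number from compound 2 to compound 3 (0.42 log units; beyond the scatter).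

Compound 4 `CC(=O)c1ccc(/N=C2\C=C(OCc3cn(S(=O)(=O)c4ccc(C)cc4)nn3)C(=O)c3ccccc32)cc1` is not yet measured. It differs from compound 1 in one place, (acetyl in place of hydrogen on an aromatic carbon), on an aromatic carbon of a six-membered aromatic ring of carbon only. The measured steps that bear on this are the two from compound 1, where chloro or methyl entered at the same kind of aromatic carbon, and neither moved the number beyond the scatter. Among the measured compounds shown here, no acetyl analogue has been measured, so the expectation for compound 4 rests on those two steps alone and is a step of no size beyond the scatter, a 1.0-fold lower number from compound 1 to compound 4 (0.01 log units; within the scatter). Compound 4 is therefore expected to give about 5200 nM in this assay, within a range from 2000 nM to 13500 nM.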

Compound 4, half-maximal inhibitory concentration: 6270 nM
Compound 4: middle estimate off by 1.2-fold (0.08 log units), on the low side; low and high end bracket the measured number.
By their numbers in this assay, from the lowest: compounds 3, 1, 4 and 2 (each within the scatter of the next, the first and the last beyond it).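

In this assay, acetyl brings 3 heavy atoms and 1 hydrogen-bond acceptor to this aromatic carbon, yet the step stays within the scatter (a 1.2-fold higher number from compound 1 to compound 4 (0.07 log units; within the scatter)). Compound 4 also lies within the scatter of the two other substituted compounds (a 1.7-fold higher number from compound 3 to compound 4 (0.24 log units; within the scatter); a 1.5-fold lower number from compound 2 to compound 4 (0.18 log units; within the scatter)). This position, para to a large group, therefore tolerates a larger group with a carbonyl as well as it does methyl or chloro, and the gap between compound 2 and compound 3 remains the only one among these four compounds that goes beyond the scatter.

Going by these compounds, whether an amine, a carboxylic acid or a longer chain at this carbon would shift the number beyond the scatter remains open. Nothing available here accounts for these numbers.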